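The source may report more compounds than this note shows. Statements on the series, on what has been measured and on what is new or still open speak of the compounds shown alone.

In a functional assay on HEK293 cells with D(4) dopamine receptor (Homo sapiens) as the target, read by FLIPR (on this read-out lower numbers stand for an effect already at smaller amounts and higher numbers for an effect only at larger amounts of compound), three compounds have been measured so far. Compound 1 `Cc1ccccc1/C(CCN1CCN(c2ccccn2)CC1)=N/O` gives 4.2 nM. Among the measured compounds shown here, compound 2 `O/N=C(\CCN1CCN(c2ccccn2)CC1)c1ccc(F)cc1F` gives 8.9 nM, and the one step between measured neighbours, a 2.1-fold higher number from compound 1 to compound 2 (0.33 log units; beyond the scatter), is modest. Compound 3 `CCCO/N=C(\CCN1CCN(c2ccccn2)CC1)c1ccccc1` gives 320 nM and stands highest of the three, with compound 2 its nearest neighbour and compound 1 the furthest away. Compound 3 alone carries a propoxy group, and its number lies far from both of the others.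

Compound 4 `C=CCO/N=C(\CCN1CCN(c2ccccn2)CC1)c1ccccc1` has not yet been measured. Its change from compound 3 is vinyl in place of ethyl on a saturated chain carbon bound to an oxygen on an unsaturated carbon; cut one bond further out, the same change reads propyl to allyl, or propoxy to allyloxy. For the measured compounds named here, no measured step touches this part of the molecule: the step from compound 1 to compound 2 changes the group on the carbon with a double bond to nitrogen, and the wide gap between compound 3 and the other two goes with the propoxy group as a whole, which compound 4 keeps apart from the new double bond. There is thus no direct guide, and the change itself is small. A step within the usual scatter, in no fixed direction, is therefore expected, so that a 1.1-fold lower number from compound 3 to compound 4 (0.03 log units; within the scatter) stays close to nothing. Compound 4 is estimated at 300 nM in this assay, with a range of 100 nM to 900 nM.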

Compound 4, half-maximal effective concentration: 350 nM
For compound 4 the middle estimate is 1.2-fold (0.07 log units) below the measured one; measured number inside the range.
By their numbers in this assay, from the lowest: compound 1; then compound 2; then compounds 3 and 4 (each within the scatter of the next).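

In this assay, going from propoxy to allyloxy gives a 1.1-fold higher number from compound 3 to compound 4 (0.04 log units; within the scatter), so the double bond that enters with vinyl in place of ethyl brings no change that can be told from the scatter. Among the compounds shown here, until now no step had touched the group on the oxygen; this is the first reading at this position, and it shows that one small edit there, with the heavy-atom count unchanged, leaves the number where it was. No measurement shown here explains why the two chains give values so alike.

As far as these compounds go, whether this tolerance holds for a clearly different group on the oxygen, such as a longer chain like hexyl, a benzyl group or a chain ending in an amine, remains open, as a single saturated-to-unsaturated swap says little about larger changes. Also open, from the compounds shown here alone, is how much of the distance between these two compounds and compounds 1 and 2 belongs to the group on the oxygen, as compounds 1 and 2 also differ from them on the aromatic ring.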